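This account rests on a few compounds, and the source may have more. Where it says the series, first, only, none or still open, it means among the compounds named here.

Compound 1 `COc1cc(CSc2cc(Cl)c(-c3nnc(-c4ccc(Cl)cc4)s3)cc2S(=O)(=O)NC(=N)NO)cc(OC)c1OC` gives 97700 nM in a functional assay on Malme-3M cells (Homo sapiens); on this read-out lower numbers stand for stronger inhibition of growth and higher numbers for weaker inhibition of growth.
Compound 2 `COc1cc(CSc2cc(Cl)c(-c3nc(-c4ccccc4)no3)cc2S(=O)(=O)NC(=N)NO)cc(OC)c1OC` gives 13500 nM in this assay.
Compound 3 `COc1cc(CSc2cc(Cl)c(-c3nnc(-c4ccccc4)s3)cc2S(=O)(=O)NC(=N)NO)cc(OC)c1OC` gives 3090 nM in this assay.

Compound 3 therefore has the lowest number of the three, with compound 2 nearest and compound 1 furthest. Compound 4 `COc1cc(CSc2cc(Cl)c(-c3nc(-c4ccc(Cl)cc4)no3)cc2S(=O)(=O)NC(=N)NO)cc(OC)c1OC` has not yet been measured; it carries 3-(4-chlorophenyl)-1,2,4-oxadiazol-5-yl in place of 5-phenyl-1,3,4-thiadiazol-2-yl on an aromatic carbon. Going by the values given here, two measured steps bear on this, both running the opposite way: a 4.4-fold lower number from compound 2 to compound 3 (0.64 log units; beyond the scatter), and a 32-fold lower number from compound 1 to compound 3 (1.50 log units; beyond the scatter). Compound 4 reverses both changes at once, so in this assay a large rise in the number is expected, beyond the scatter. The expected step is a 65-fold higher number from compound 3 to compound 4 (1.81 log units; beyond the scatter). Compound 4 is estimated at 200000 nM, in a range from 40000 nM to 700000 nM, and it may reach a limit of the assay.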

Compound 4, concentration for 50% growth inhibition: 7760 nM
Compound 4: the middle estimate sits 26-fold (1.41 log units) above what was measured, and the stated range ends above it.
By their numbers in this assay, from the lowest: compound 3; then compounds 4 and 2 (each within the scatter of the next); then compound 1.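

In this assay, chloro in place of hydrogen on the phenyl of the oxadiazole group gives a 1.7-fold lower number from compound 2 to compound 4 (0.24 log units; within the scatter), so here it leaves the number within the scatter. Moving to the oxadiazole gives a 13-fold lower number from compound 1 to compound 4 (1.10 log units; beyond the scatter) with chloro on both groups, but a much smaller a 2.5-fold higher number from compound 3 to compound 4 (0.40 log units; beyond the scatter) when the 5-phenyl-1,3,4-thiadiazol-2-yl group leaves and 3-(4-chlorophenyl)-1,2,4-oxadiazol-5-yl enters. What chloro does therefore depends on the group that carries it: the same change on two cores in this assay, a 32-fold lower number (1.50 log units; beyond the scatter) from compound 1 to compound 3 and a 1.7-fold higher number (0.24 log units; within the scatter) from compound 4 to compound 2, 55-fold (1.74 log units) apart, beyond the scatter of two such steps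

The compounds shown leave open how fluoro or an amine in place of that chloro would behave on either group.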